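The source may report more compounds than this note shows. Statements on the series, on what has been measured and on what is new or still open speak of the compounds shown alone.

Compound 2 `O=C(Nc1cccc2ccccc12)NC1CCc2ccccc2N(CC(=O)N2CCCC2)C1=O` is the weaker of the two measured compounds in an assay with Cholecystokinin receptor type A (Rattus norvegicus) as the target, read by CCK-8 assay; a lower number here means a stronger inhibitor, a higher number a weaker inhibitor: compound 2 gives 1700 nM, while compound 1 `CC(C)(C)OC(=O)CN1C(=O)C(NC(=O)Nc2ccc(Cl)cc2)CCc2ccccc21` gives 350 nM, a gap beyond the usual scatter. Compound 3 `CC(C)(C)OC(=O)CN1C(=O)C(NC(=O)Nc2cccc3ccccc23)CCc2ccccc21` differs from compound 2 by tert-butoxy in place of pyrrolidin-1-yl on a carbonyl carbon, so compound 3 shares its tert-butoxy group with compound 1. For the measured compounds named here, no measured pair shows this change alone, so the expected step is uncertain; a modest lowering is expected for compound 3 because compound 1 with the same tert-butoxycarbonyl group gives 350 nM. Compound 3 is therefore estimated at 600 nM, with a range from 150 nM to 2500 nM, an expected step of a 2.8-fold lower number from compound 2 to compound 3 (0.45 log units; beyond the scatter).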

Compound 3, half-maximal inhibitory concentration: 960 nM
Beside the measured number, compound 3's estimate is 1.6-fold (0.20 log units) below it; low and high end bracket the measured number.
By their numbers in this assay, from the lowest: compound 1; then compounds 3 and 2 (each within the scatter of the next).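

In this assay, tert-butoxy in place of pyrrolidin-1-yl on a carbonyl carbon gives a 1.8-fold lower number from compound 2 to compound 3 (0.25 log units; within the scatter), so this change alone stays within the scatter. Naphthalen-1-yl in place of 4-chlorophenyl on an amide-type nitrogen gives a 2.7-fold higher number from compound 1 to compound 3 (0.44 log units; beyond the scatter), a modest step, and of the two changes only this one lies beyond the scatter. Nothing measured here accounts for either step.

From the compounds shown here alone, whether dimethylamino or a carboxylic acid on that carbonyl carbon would hold the number stays open. So does whether 4-chlorophenyl on the nitrogen would give the same step with pyrrolidin-1-yl on the carbonyl.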